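The compounds below may be only part of what the source reports. "The series", "measured", "known", "first", "only" and "open" are said of these compounds alone.

Compound 1 `COc1cccc(/C=C/CC(=O)Nc2nc3ccccc3c(=O)s2)c1` gives 115 nM in an assay on CHO cells for displacement of a labelled ligand from adenosine receptor A3 (Homo sapiens), read by scintillation counting, with a stated time of 60 min; a higher number here means a weaker inhibitor, a lower number a stronger inhibitor. Compound 2 `O=C(C/C=C/c1ccccc1)Nc1nc2ccccc2c(=O)s1` gives 158 nM in this assay.

Among the compounds with values here, on these two numbers compound 2 cannot be told apart from compound 1: the only measured step, a 1.4-fold higher number from compound 1 to compound 2 (0.14 log units; within the scatter), lies within the usual scatter, so neither compound can be called the stronger inhibitor.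

Compound 3 `O=C(C/C=C/c1ccc(Cl)c(Cl)c1)Nc1nc2ccccc2c(=O)s1` differs from compound 2 by 3,4-dichlorophenyl in place of phenyl on a double-bonded chain carbon bound to a double-bonded chain carbon. Within the data shown here, no measured pair involves chlorine on this ring. Among the measured compounds shown here, the one step that bears on the change is a 1.4-fold higher number from compound 1 to compound 2 (0.14 log units; within the scatter), which also alters a substituent on the phenyl ring of the chain; it was within the scatter, and it gives no reason to expect that substitution on this ring moves the number far. The expectation for compound 3 is therefore a step of no more than the scatter, a 1.1-fold lower number from compound 2 to compound 3 (0.02 log units; within the scatter), in either direction. Compound 3 is estimated to give 150 nM in this assay, with a range from 50 nM to 450 nM.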

Compound 3, inhibition constant: > 1000 nM
Compound 3: no number, only a limit (the forecaster's own chance of this, stated with the estimate: 3%); at least 6.6-fold (0.82 log units) between middle value and limit.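

Compound 3 reaches only a limit in this assay (> 1000 nM), not a number. The earlier pair had shown only a step within the scatter on the phenyl ring of the chain, whereas this result shows that what the ring carries on the double-bonded chain carbon can matter: 3,4-dichlorophenyl gives an at least 6.3-fold higher number from compound 2 to compound 3 (0.80 log units; beyond the scatter) when it replaces phenyl, and an at least 8.6-fold higher number from compound 1 to compound 3 (0.93 log units; beyond the scatter) when it replaces 3-methoxyphenyl. Both steps are minimum sizes, and how far compound 3 truly lies from the other two cannot be read from the result: the limit of > 1000 nM in this assay, at which 1 of the 3 values shown sits.

From the compounds shown here alone, the two chlorine atoms enter together, so it remains open whether a single chlorine on this ring would give a step of the same size. Also open, going by these compounds, is how a methyl, an amine or a carboxylic acid on this ring, or a longer chain in place of the present one, would read in this assay against the values of compound 1 and compound 2.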